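Trifluoromethyl in place of chloro: a cytotoxicity estimate

The source may report more compounds than this note shows. Statements on the series, on what has been measured and on what is new or still open speak of the compounds shown alone.

Of the compounds shown here, two built on a shared core have been measured so far in an ADME assay on L6 cells (Rattus norvegicus) for cytotoxicity, read by resazurin assay, with a stated time of 72 h (a higher number here means a weaker inhibitor, a lower number a stronger inhibitor), and both give high numbers. Compound 1 (`OC(c1ccc(Cl)cc1)(c1ccc(C(F)(F)F)cc1)c1cccnc1`) gives 56400 nM and compound 2 (`OC(c1ccc(Cl)cc1)(c1cccnc1)c1ccc(Cl)cc1F`) gives 59400 nM in that measure, which places compound 2 within the scatter of compound 1.

Compound 3 (`OC(c1ccc(Cl)cc1)(c1cccnc1)c1ccc(C(F)(F)F)cc1F`) departs from compound 2 in one place, with trifluoromethyl in place of chloro on an aromatic carbon. The new group stands meta to a fluoro group and para to a large group. Within the data shown here, the two measured compounds differ in more than one place, so no measured single-place step is available to size this change.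

Compound 1 does carry a trifluoromethyl group, and its 56400 nM lies close to the value of compound 2. No change beyond the scatter is therefore expected in this assay and no direction is favoured. The estimated step is a 1.1-fold lower number from compound 2 to compound 3 (0.03 log units; within the scatter) and is expected to stay within the scatter. For compound 3 the expected value is 55000 nM with an estimated range of 28000 nM to 105000 nM in this measure.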

Compound 3, half-maximal inhibitory concentration: 57400 nM
Compound 3: middle estimate off by 1.0-fold (0.02 log units), on the low side, and the stated range covers the measured number.
By their numbers in this assay, from the lowest: compounds 1, 3 and 2 (each within the scatter of the next).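

In this assay, among these compounds, the trifluoromethyl group at this position, on an aromatic carbon para to a large group and meta to a fluoro group, gives a 1.0-fold lower number from compound 2 to compound 3 (0.01 log units; within the scatter) as the first measured single-place step on the shared core, so replacing chloro with this group leaves the number within the scatter. The second listed change, fluoro in place of hydrogen on an aromatic carbon, gives a 1.0-fold higher number from compound 1 to compound 3 (0.01 log units; within the scatter) and also stays within the scatter, which means that neither single-place change around compound 3 separates it from its neighbour in this measure. Nothing shown here gives a measured basis for explaining either step.

The compounds shown leave open whether the trifluoromethyl-for-chloro step would remain this small without the fluoro group, since the chloro counterpart of compound 1 lacking that fluoro group does not appear among them. They also leave open whether a markedly different group at this position, such as an amine or a carboxylic acid, would move the number beyond the scatter.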